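A few compounds are considered here, and "the series" means these few. Any claim that something is new, unique, unknown or untested is made for them only; others in the source may bear on it.

Series notes, cytotoxicity. In an ADME assay on HEL cells (Homo sapiens) for cytotoxicity, with a stated time of 3 days (on this read-out higher numbers stand for lower toxicity in this test and lower numbers for higher toxicity in this test), compound 1 `Cc1cc(-c2cccc(C#N)c2)cn2c(CSCCc3ccccc3)cnc12` gives only a limit, > 50 ug/mL. Compound 2 `Cc1cc(I)c2ncc(CSCCc3ccccc3)n2c1` likewise returns a limit in this assay, > 50 ug/mL. Compound 3 `c1ccc(CCSCc2cnc3ccc(-c4ccccc4)cn23)cc1` gives a number in this assay, 9.9 ug/mL. Among the compounds with values here, compound 1 therefore stands at the limit of > 50 ug/mL in this assay, at which 2 of the 3 values shown sit; no single-change step between the measured compounds is available, and the record offers no further ordering. Compound 4 `Cc1cc(-c2cccc(O)c2)cn2c(CSCCc3ccccc3)cnc12` carries the change (hydroxy in place of cyano on an aromatic carbon). For this change the expectation is no step beyond the scatter, a number no higher from compound 1 to compound 4 (the limit leaves the size open), in either direction. On that basis compound 4 is expected to give 50 ug/mL in this assay, within 15 ug/mL to 150 ug/mL, most likely again as a limit rather than a number.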

Compound 4, half-maximal cytotoxic concentration: 50 ug/mL
Estimate against measurement, compound 4: no gap at the digits printed; the measured number falls inside the stated range.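

In this assay, the change from 3-cyanophenyl to 3-hydroxyphenyl gives a number no higher from compound 1 to compound 4 (the limit leaves the size open). Compound 1 holds only a limit, > 50 ug/mL. With hydroxy on this aromatic carbon, compound 4 supplies a true number for this position, and it sits at the same printed figure as that limit: the limit of > 50 ug/mL in this assay, at which 2 of the 4 values shown sit.

The compounds shown leave open how an amine or a carboxylic acid in place of the hydroxy would read in this assay. The size of the step itself cannot be read.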